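From naphthalen-1-yl to thiophen-2-yl: notes on the series

This account rests on a few compounds, and the source may have more. Where it says the series, first, only, none or still open, it means among the compounds named here.

For the measured compounds named here, in a functional assay on COLO 205 cells (Homo sapiens) for inhibition, read by sulforhodamine B assay, with a stated time of 48 h, tested at 50 uM (a lower number here means less inhibition of growth, a higher number more inhibition of growth at the concentration tested), compound 1 (`COc1cc(/C=C/C(=O)/C=C/c2cccc3ccccc23)ccc1OCc1cn(CCOc2cc(=O)oc3ccccc23)nn1`) gives 85%, the highest of the three numbers so far. Compound 3 (`COc1cc(/C=C/C(=O)/C=C/c2ccco2)ccc1OCc1cn(CCCOc2cc(=O)oc3ccccc23)nn1`) gives 59% and compound 2 (`COc1cc(/C=C/C(=O)/C=C/c2cccc3ccccc23)ccc1OCc1cn(CCCCCOc2cc(=O)oc3ccccc23)nn1`) gives 40%, both lower than compound 1 by more than the scatter.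

Compound 4 (`COc1cc(/C=C/C(=O)/C=C/c2cccs2)ccc1OCc1cn(CCOc2cc(=O)oc3ccccc23)nn1`) has not yet been measured. Relative to compound 1, it carries thiophen-2-yl in place of naphthalen-1-yl on a double-bonded chain carbon bound to a double-bonded chain carbon.

Going by the values given here, no two measured compounds differ in one place only, so the size of this change cannot be read directly from the data. Compound 3 also lacks naphthalen-1-yl and gives 59%, but it differs from compound 1 elsewhere as well, so it is only a loose guide. A moderate downward step is expected in this assay, estimated as a number 20 percentage points lower from compound 1 to compound 4 (beyond the scatter). For compound 4 the estimated value is 65%, with an expected range from 42% to 85%.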

Compound 4, percent growth inhibition at one concentration: 66%
Estimate against measurement, compound 4: 1 percentage points below; the range from low to high includes it.
By their numbers in this assay, from the lowest: compound 2; then compounds 3 and 4 (each within the scatter of the next); then compound 1.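

In this assay, for the compounds shown here, the first single-place comparison is now available: thiophen-2-yl in place of naphthalen-1-yl on a double-bonded chain carbon bound to a double-bonded chain carbon gives a number 19 percentage points lower from compound 1 to compound 4 (beyond the scatter) with the rest of the structure unchanged. The position therefore responds to this change, but naphthalen-1-yl is not required for growth inhibition at the concentration tested, since compound 4 still gives 66% in this assay. Nothing at hand gives a reason for the step.

From the compounds shown here alone, it remains open whether a phenyl or pyridin-3-yl group at this place would read closer to thiophen-2-yl or to naphthalen-1-yl. Also open, going by these compounds, is whether the same change would give a step of similar size with the longer chain of compound 2.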